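Amide-nitrogen aryl change from compound 3 to compound 4

A few compounds are considered here, and "the series" means these few. Any claim that something is new, unique, unknown or untested is made for them only; others in the source may bear on it.

Three compounds of the shared core have numbers in an assay on isolated protein for inhibition of histone deacetylase 4 (Homo sapiens), with a stated time of 1 h; a lower number here means a stronger inhibitor, a higher number a weaker inhibitor. Compound 1 `Cc1ccc(NC(=O)COc2ccc3cc(/C=C4/SC(=O)NC4=O)ccc3c2)cc1` gives 1700 nM. Compound 2 `CCOc1ccc2nc(NC(=O)COc3ccc4cc(/C=C5/SC(=O)NC5=O)ccc4c3)sc2c1` gives 3600 nM. Compound 3 `O=C(COc1ccc2cc(/C=C3/SC(=O)NC3=O)ccc2c1)Nc1cccc(F)n1` gives 840 nM, the lowest of the three; the nearest is compound 1 and the furthest is compound 2. For the measured compounds named here, the only single-point step among them, a 2.0-fold lower number from compound 1 to compound 3 (0.31 log units; beyond the scatter), is modest and beyond the scatter.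

Compound 4 `O=C(COc1ccc2cc(/C=C3/SC(=O)NC3=O)ccc2c1)Nc1cccc(C(F)(F)F)c1` differs from compound 3 by 3-(trifluoromethyl)phenyl in place of 6-fluoropyridin-2-yl on an amide-type nitrogen. Going by the values given here, no measured step covers an aryl carrying a trifluoromethyl group at this nitrogen; the step of a 2.0-fold lower number from compound 1 to compound 3 (0.31 log units; beyond the scatter) bears on it only as the sole exchange at the same place, and there the all-carbon aryl of compound 1 gave the higher number. The expectation for this assay is therefore a small rise from compound 3 to compound 4, a 1.5-fold higher number from compound 3 to compound 4 (0.19 log units; within the scatter), not clearly beyond the scatter. Compound 4 is estimated at 1300 nM, with a range of 500 nM to 3500 nM.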

Compound 4, half-maximal inhibitory concentration: 2500 nM
Compound 4: the middle estimate sits 1.9-fold (0.28 log units) below what was measured, and the stated range covers the measured number.
By their numbers in this assay, from the lowest: compound 3; then compounds 1, 4 and 2 (each within the scatter of the next, the first and the last beyond it).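

In this assay, a second carbon-only aryl on the amide-type nitrogen also sits above 6-fluoropyridin-2-yl, with a 3.0-fold higher number from compound 3 to compound 4 (0.47 log units; beyond the scatter), so the earlier exchange at this place is no longer a lone observation. The two carbon-only aryls do not separate, with a 1.5-fold higher number from compound 1 to compound 4 (0.17 log units; within the scatter), so 3-(trifluoromethyl)phenyl and 4-methylphenyl cannot be ranked at this nitrogen. No measurement is available that explains the step.

The fluorine and the ring nitrogen of 6-fluoropyridin-2-yl remain unseparated, and a plain pyridin-2-yl alongside a 3-fluorophenyl would divide their contributions. From the compounds shown here alone, compound 3 at 840 nM remains the lowest number, and whether an aryl carrying an amine or a carboxylic acid at this nitrogen would go lower stays open.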